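A few compounds are considered here, and "the series" means these few. Any claim that something is new, unique, unknown or untested is made for them only; others in the source may bear on it.

Working notes on the series. The shared core carries a substituted aniline amide; compound 1 is `COc1ccc(C)cc1NC(=O)CN1CCN(S(=O)(=O)N2CCC(C)CC2)CC1`, compound 2 is `CCOc1ccc(Cl)cc1NC(=O)CN1CCN(S(=O)(=O)N2CCC(C)CC2)CC1` and compound 3 is `COc1ccc(C(F)(F)F)cc1NC(=O)CN1CCN(S(=O)(=O)N2CCC(C)CC2)CC1`. In an assay on HEK293 cells for inhibition of potassium channel subfamily T member 1 (Homo sapiens), read by thallium flux (on this read-out higher numbers stand for weaker inhibition and lower numbers for stronger inhibition), compound 1 reports only a limit, > 10000 nM. In this assay compound 2 gives 7100 nM. In this assay, among the measured compounds shown here, compound 3 gives 2400 nM, the lowest of the two numbers known, with compound 2 the nearest. Of the measured steps, an at least 1.4-fold lower number from compound 1 to compound 2 (0.14 log units; that floor lies within the scatter), and an at least 4.1-fold lower number from compound 1 to compound 3 (0.61 log units; beyond the scatter). Both start from compound 1, whose value is a limit (the limit of > 10000 nM in this assay, at which 1 of the 3 values shown sits), so each step is itself only a floor.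

The next compound, compound 4, is `COc1ccc(Br)cc1NC(=O)CN1CCN(S(=O)(=O)N2CCC(C)CC2)CC1`; it differs from compound 3 by bromo in place of trifluoromethyl on an aromatic carbon. For the measured compounds named here, the only measured step at this aromatic carbon is the one from compound 1 to compound 3, where trifluoromethyl entering in place of methyl lowered the number at least modestly. Bromo has no measured counterpart in the series, so the change is taken as roughly neutral to slightly weakening, with wide uncertainty. The step expected here is a 1.5-fold higher number from compound 3 to compound 4 (0.16 log units; within the scatter). For compound 4 the estimate in this assay is 3500 nM, with a range from 1500 nM to 9000 nM.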

Compound 4, half-maximal inhibitory concentration: 1400 nM
Estimate against measurement, compound 4: 2.5-fold (0.40 log units) above, and the stated range ends above it.
By their numbers in this assay, from the lowest: compounds 4 and 3 (each within the scatter of the next); then compound 2. At a limit, above all of these: compound 1.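

At the aromatic carbon para to a methoxy group, this assay does not separate bromo from trifluoromethyl, with a 1.7-fold lower number from compound 3 to compound 4 (0.23 log units; within the scatter), even though bromo has 1 heavy atom and trifluoromethyl has 4 heavy atoms. The comparison with compound 2 gives a 5.1-fold lower number from compound 2 to compound 4 (0.71 log units; beyond the scatter), which lies beyond the scatter, but that step exchanges the whole 5-chloro-2-ethoxyphenyl for 5-bromo-2-methoxyphenyl, so it does not assign the difference to the halogen or to the ether chain. With bromo in place of methyl there is now a second replacement at this carbon with a step beyond the scatter, namely an at least 7.1-fold lower number from compound 1 to compound 4 (0.85 log units; beyond the scatter), and this too is only a floor, as compound 1 gives a limit and not a number: the limit of > 10000 nM in this assay, at which 1 of the 4 values shown sits.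

Open, on these data alone, is how a nitrile, an amine or a carboxylic acid would read at this aromatic carbon, and whether chloro would match bromo with the methoxy group kept. Open too, as far as these compounds go, is which of the two differing groups in compound 2, the chloro or the ethoxy, carries its gap to compound 4.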